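The compounds below may be only part of what the source reports. "The series", "measured", "known", "first", "only" and "open" are said of these compounds alone.

In a physicochemical assay for solubility (on this read-out higher numbers stand for higher solubility and lower numbers for lower solubility), compound 1 `CNC(=O)c1cc(C(=O)NC2CC2)cn(Cc2nccc3[nH]ccc23)c1=O` gives 73 ug/mL. Compound 2 `CNC(=O)c1cc(C(=O)NC2CC2)cn(CC2CCOCC2)c1=O` gives >= 165 ug/mL, which is a limit and not a number. Compound 3 `CNC(=O)c1cc(C(=O)NC2CC2)cn(Cc2cccc3cc[nH]c23)c1=O` is not yet measured and differs from compound 2 as follows: 1H-indol-7-yl in place of oxan-4-yl on a saturated chain carbon bound to an aromatic nitrogen. Among the measured compounds shown here, compound 3 carries a five-membered and a six-membered aromatic ring, as compound 1 does, so the one measured step bearing on this, an at least 2.2-fold higher number from compound 1 to compound 2 (0.35 log units; beyond the scatter), is expected to reverse, giving a lower number in this assay, beyond the scatter. The estimated step is an at least 3.6-fold lower number from compound 2 to compound 3 (0.56 log units; beyond the scatter). For compound 3 the estimated value is 45 ug/mL, with an expected range from 15 ug/mL to 120 ug/mL.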

Compound 3, solubility: >= 144 ug/mL
Compound 3: no number, only a limit; the forecaster's own chance of this, stated with the estimate: 10%; middle value at least 3.2-fold (0.50 log units) from the limit.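

In this assay compound 3 gives a limit and not a number: the limit of >= 144 ug/mL in this assay, at which 1 of the 3 values shown sits.

Exchanging the aromatic group on the saturated chain carbon bound to an aromatic nitrogen gives an at least 1.9-fold higher number from compound 1 to compound 3 (0.29 log units; that floor lies within the scatter), so no difference beyond the scatter is established. A group with a five-membered and a six-membered aromatic ring is therefore not tied to a low number at this position, as 1H-indol-7-yl in compound 3 goes against that reading.

Compound 2 and compound 3 both stand as limits, and the step between them cannot be read. On these data alone, whether an amine or a carboxylic acid at this position would give a number in this assay stays open.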